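The source may hold more compounds than are shown below. What is called first, only, known or untested is meant among the compounds shown, and "the series" means these compounds.

In a functional assay on CHO cells with adenosine receptor A1 (Homo sapiens) as the target, read by cAMP accumulation and immunoassay, with a stated time of 6 min, tested at 0.1 uM (on this read-out lower numbers stand for a stronger effect and higher numbers for a weaker effect at the one concentration tested), the three measured compounds gave these results:

Compound 1 `Nc1scc(CN2CCN(c3cc(Cl)cc(Cl)c3)CC2)c1C(=O)c1ccc(Cl)cc1` gives -22%.
Compound 2 `Nc1scc(CN2CCN(c3cccnc3)CC2)c1C(=O)c1ccc(Cl)cc1` gives 3.4%.
Compound 3 `Nc1scc(CN2CCN(c3ccc(F)c(Cl)c3)CC2)c1C(=O)c1ccc(Cl)cc1` gives -21%.

Compound 3 stands second highest of the three numbers. The step of a number 1 percentage points higher from compound 1 to compound 3 (within the scatter) lies within the scatter, so the two values cannot be told apart, whereas the step of a number 24.4 percentage points lower from compound 2 to compound 3 (beyond the scatter) is a modest one beyond the scatter, as is a number 25.4 percentage points higher from compound 1 to compound 2 (beyond the scatter).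

Compound 4 `Nc1scc(CN2CCN(CCCc3ccc(Cl)cc3)CC2)c1C(=O)c1ccc(Cl)cc1` differs from compound 3 in one place: 3-(4-chlorophenyl)propyl in place of 3-chloro-4-fluorophenyl on an amine nitrogen in a ring. Every measured step swapped one aromatic ring for another directly on that ring nitrogen; none replaced the aromatic ring with a chain carrying an aromatic ring further out. The two steps that did bear on aryl-for-aryl swaps were modest, and the closest one, a number 1 percentage points higher from compound 1 to compound 3 (within the scatter), was within the scatter. Within the data shown here, no measured step tests this kind of change, so the expected step of a number 13 percentage points higher from compound 3 to compound 4 (beyond the scatter) is uncertain and could fall on either side. The estimate for compound 4 in this assay is -8%, expected to lie between -35% and 20%.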

Compound 4, a percentage reported as activity, at one concentration (the size of the read-out at that concentration, not a potency): -3%
Estimate against measurement, compound 4: 5 percentage points below, and the stated range covers the measured number.
By their numbers in this assay, from the lowest: compounds 1 and 3 (each within the scatter of the next); then compounds 4 and 2 (each within the scatter of the next).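

In this assay, among these compounds, this is the first change at the ring nitrogen that moves the aromatic ring out onto a chain instead of swapping one directly attached ring for another, and the number does move: a number 18 percentage points higher from compound 3 to compound 4 (beyond the scatter) and a number 19 percentage points higher from compound 1 to compound 4 (beyond the scatter) are both modest steps beyond the scatter. Set against the pyridin-3-yl group, the chain gives a number 6.4 percentage points lower from compound 2 to compound 4 (within the scatter) and this step lies within the scatter, so the 3-(4-chlorophenyl)propyl group cannot be told apart from that ring here. Nothing measured here explains these shifts.

From the compounds shown here alone, what stays open is whether the length of the chain or the chlorine on its ring matters more. A benzyl group, a 2-phenylethyl chain and a plain 3-phenylpropyl group would each help to separate those two features.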